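The compounds below may be only part of what the source reports. "The series", "measured", "known", "first", "only" and "open" are said of these compounds alone.

Compound 1 `CCc1ccc(NC2=CC(=O)c3c(nc4n3[C@H]3OC[C@@H](O)[C@H]3OC4)C2=O)cc1`: 6510 nM
Compound 2 `Cc1ccc(NC2=CC(=O)c3c(nc4n3[C@H]3OC[C@@H](O)[C@H]3OC4)C2=O)cc1`: 6590 nM
Compound 3 `COc1ccc(NC2=CC(=O)c3c(nc4n3[C@H]3OC[C@@H](O)[C@H]3OC4)C2=O)cc1`: > 8000 nM (a limit, not a number)

All three compounds were tested in a functional assay on HeLa cells (Homo sapiens) for inhibition, read by sulforhodamine B assay; on this read-out higher numbers stand for weaker inhibition and lower numbers for stronger inhibition. Compound 3 has no exact value and stands only at the limit of > 8000 nM in this assay, at which 1 of the 3 values shown sits.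

The change to compound 4 `COc1cccc(NC2=CC(=O)c3c(nc4n3[C@H]3OC[C@@H](O)[C@H]3OC4)C2=O)c1` is 3-methoxyphenyl in place of 4-methoxyphenyl on an amine nitrogen. The two compounds have the same atoms, joined differently. Among the compounds with values here, no measured step makes this kind of change, so the nearest guide comes from swapping the group on the same ring. That swap gives an at least 1.2-fold higher number from compound 2 to compound 3 (0.08 log units; that floor lies within the scatter) and an at least 1.2-fold higher number from compound 1 to compound 3 (0.08 log units; that floor lies within the scatter). Each is only a floor. The true size of the step cannot be read from a limit. The remaining measured step, a 1.0-fold higher number from compound 1 to compound 2 (0.01 log units; within the scatter), is also small.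

With an at least 1.2-fold higher number from compound 2 to compound 3 (0.08 log units; that floor lies within the scatter) this small, no step beyond the scatter is expected in this assay, although this is weak evidence for a change of this kind. The expected step is an at least 1.0-fold lower number from compound 3 to compound 4 (0.02 log units; that floor lies within the scatter). For compound 4, the estimated value is 7500 nM, with an expected range of 4000 nM to 14000 nM.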

Compound 4, half-maximal inhibitory concentration: > 8000 nM
Compound 4 ended at the assay's limit; the forecaster's own chance of this, stated with the estimate: 40%; middle value at least 1.0-fold (0.02 log units) from the limit.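

In this assay compound 4 gives > 8000 nM, which is a limit and not a number. With the methoxy group moved, as 3-methoxyphenyl in place of 4-methoxyphenyl on the amine nitrogen, an exact value is still missing, and the step between these two compounds cannot be read because both rest on the same limit: the limit of > 8000 nM in this assay, at which 2 of the 4 values shown sit. Compared with the two compounds that have exact values, the result gives an at least 1.2-fold higher number from compound 2 to compound 4 (0.08 log units; that floor lies within the scatter) and an at least 1.2-fold higher number from compound 1 to compound 4 (0.08 log units; that floor lies within the scatter), so neither comparison shows a change beyond the scatter.

As far as these compounds go, how far compound 3 and compound 4 truly lie past the limit stays open. So does the effect of other groups on this phenyl ring, such as a hydroxyl, an amine or a carboxylic acid.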